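A Nicotinoyl Ester on a Hexokinase-2 Scaffold

A few compounds are considered here, and "the series" means these few. Any claim that something is new, unique, unknown or untested is made for them only; others in the source may bear on it.

Measured compounds:
Compound 1 `C=C1CC[C@H]2[C@@](C)(CCC(=O)N[C@@]2(C)COC(=O)[C@H](N)CC(C)C)[C@@H]1/C=C/C1=CCOC1=O` — > 50000 nM
Compound 2 `C=C1CC[C@H]2[C@@](C)(CC[C@@H](O)[C@@]2(C)NC=O)[C@@H]1/C=C/C1=CCOC1=O` — > 50000 nM

In an assay for inhibition of hexokinase-2 (Homo sapiens), read by coupled enzyme assay, with a stated time of 10 min, in the presence of a further agent that is not named here (on this read-out lower numbers stand for stronger inhibition and higher numbers for weaker inhibition), compound 1 gives > 50000 nM, which is a limit of the assay rather than a number. Compound 2 in this assay likewise gives > 50000 nM, again a limit. Both values sit at the limit of > 50000 nM in this assay, at which 2 of the 2 values shown sit, so compound 2 stands level with compound 1 on the numbers shown, and no step between the two can be sized. Compound 3 `C=C1CC[C@H]2[C@@](C)(CC[C@@H](OC(=O)c3cccnc3)[C@@]2(C)NC=O)[C@@H]1/C=C/C1=CCOC1=O` has not yet been measured in this assay. It differs from compound 2 by (pyridin-3-yl)carbonyl in place of hydrogen on an oxygen on a saturated carbon. Within the data shown here, with no measured step between compounds to lean on, and with compound 2 resting at the limit of > 50000 nM in this assay, at which 2 of the 2 values shown sit, no movement beyond the usual scatter is expected. The expected step is a number no higher from compound 2 to compound 3 (the limit leaves the size open). Compound 3 is therefore expected to give 50000 nM, within the range 20000 nM to 200000 nM, most likely again reported only as a limit.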

Compound 3, half-maximal inhibitory concentration: > 50000 nM
Compound 3 was reported as a limit (the forecaster's own chance of this, stated with the estimate: 80%); the middle value lies on the limit itself.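

In this assay compound 3 gives > 50000 nM, which is a limit of the assay and not a number. Among these compounds, compound 2 also rests on a limit, so no step from compound 2 to compound 3 can be read. The compounds shown leave open whether (pyridin-3-yl)carbonyl in place of hydrogen changes the read-out at all, and what on the shared core would bring a measurable value.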